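This account rests on a few compounds, and the source may have more. Where it says the series, first, only, none or still open, it means among the compounds named here.

Measured so far:
- compound 1, `COc1cc(C)c(S(=O)(=O)N(C)CCOCC(=O)N2CCC(C(C)(C)CN(C)C)CC2)c(C)c1`, gives 36% in an ADME assay on microsomes from liver (Homo sapiens) for metabolic stability, with a stated time of 30 min, tested at 1 uM; on this read-out lower numbers stand for a less stable compound and higher numbers for a more stable compound
- compound 2, `COc1cc(C)c(S(=O)(=O)N(C)CCOCC(=O)N(C)Cc2ccc(C3=NCCN3)cc2)c(C)c1`, gives 57% in this assay
- compound 3, `COc1cc(C)c(S(=O)(=O)N(C)CCOCC(=O)N2CCC(C3CCN(C(C)C)CC3)CC2)c(C)c1`, gives 23% in this assay

Compound 3 stands lowest of the three in this assay: its nearest neighbour is compound 1, and compound 2 lies furthest above it. Among the compounds with values here, the only single-place step among the measured compounds is a number 13 percentage points lower from compound 1 to compound 3 (beyond the scatter), a modest drop that goes with the exchange of one saturated-ring substituent for another.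

Compound 4, `COc1cc(C)c(S(=O)(=O)N(C)CCOCC(=O)N2CCC(C3CCN(C)CC3)CC2)c(C)c1`, is not yet measured. It differs from compound 3 in one place: methyl in place of isopropyl on an amine nitrogen in a ring. Within the data shown here, no measured pair shares this exchange of one group on a ring amine nitrogen for a smaller one, so nothing here speaks directly to its size. Among the measured compounds shown here, the one step known, from compound 1 to compound 3, touched the same region of the molecule and stayed modest, which argues for a small change at most. For compound 4, a result near that of compound 3 is expected, a number 5 percentage points higher from compound 3 to compound 4 (within the scatter), within the scatter. The estimate for compound 4 is 28%, in a range from 14% to 44%.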

Compound 4, percent of the compound remaining: 23%
Compound 4: middle estimate off by 5 percentage points, on the high side; the range from low to high includes it.
By their numbers in this assay, from the lowest: compounds 3 and 4 (each within the scatter of the next); then compound 1; then compound 2.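

In this assay, replacing isopropyl with methyl on the amine nitrogen in the ring gives no change at the digits printed from compound 3 to compound 4 (within the scatter) and so does not separate these two groups at this position. The step from the 1-((dimethylamino)methyl)-1-methylethyl compound also holds with the smaller group, giving a number 13 percentage points lower from compound 1 to compound 4 (beyond the scatter) to stand beside the earlier a number 13 percentage points lower from compound 1 to compound 3 (beyond the scatter); for these two compounds, the drop does not depend on which of the two groups sits on that nitrogen. Nothing available explains either step.

From the compounds shown here alone, two groups cannot show how this position responds more widely, so a trend with group size stays unknown. Going by these compounds, the effect of a plain hydrogen on this nitrogen, an acetyl group that turns the amine into an amide, or a longer chain ending in a carboxylic acid remains open.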